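The source may hold more compounds than are shown below. What is called first, only, known or untested is meant among the compounds shown, and "the series" means these compounds.

Measured so far in an assay on isolated protein for inhibition of acid-sensing ion channel 3 (Homo sapiens), read by patch clamp; on this read-out higher numbers stand for weaker inhibition and lower numbers for stronger inhibition:
- compound 1, `N=C(N)c1ccc2[nH]c(-c3cc(F)cc(Br)c3)cc2c1`, 59000 nM
- compound 2, `N=C(N)c1ccc2[nH]c(-c3cc(F)cc(Cl)c3)cc2c1`, 278000 nM

Going by the values given here, compound 2 stands at the higher of the two numbers measured in this assay, with compound 1 as its only neighbour; the step from the one to the other, a 4.7-fold higher number from compound 1 to compound 2 (0.67 log units; beyond the scatter), is beyond the scatter and concerns only the halogen on the pendant ring.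

Compound 3, `N=C(N)c1ccc2[nH]c(-c3cc(N)cc(Cl)c3)cc2c1`, is the next compound of the series. Its change from compound 2 is amino in place of fluoro on an aromatic carbon. Among the compounds with values here, no measured step bears directly on this exchange: the only step known swaps one halogen for another on the same ring and says nothing about an amino group in place of fluoro. The expectation for compound 3 therefore rests on the level of compound 2 alone, with wide bounds in both directions. Compound 3 is expected to sit near compound 2 in this assay, giving 150000 nM with a range of 30000 nM to 600000 nM. Against compound 2 this means an expected step of a 1.9-fold lower number from compound 2 to compound 3 (0.27 log units; within the scatter), which may fall within the scatter.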

Compound 3, half-maximal inhibitory concentration: 95000 nM
Estimate against measurement, compound 3: 1.6-fold (0.20 log units) above, within the range that was stated.
By their numbers in this assay, from the lowest: compounds 1 and 3 (each within the scatter of the next); then compound 2.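

In this assay, the place held by fluoro proves responsive as well, not only the place of the halogen: with the chloro group held constant, amino in place of fluoro gives a 2.9-fold lower number from compound 2 to compound 3 (0.47 log units; beyond the scatter). The series thus gains its first substituent on this ring that is not a halogen, and the exchange runs toward stronger inhibition, with amino bringing 1 hydrogen-bond donor and 1 hydrogen-bond acceptor where fluoro has 0 of either. No measured evidence speaks to what lies behind this shift.

A single exchange leaves open whether the result is particular to amino or would follow from other replacements of fluoro at this place, a question that a hydroxyl, a methoxy group or an acetamide there would help to settle. Also open, from the compounds shown here alone, is whether the halogen step, a 4.7-fold higher number from compound 1 to compound 2 (0.67 log units; beyond the scatter), carries over once amino replaces fluoro, which a bromo compound bearing the amino group would show.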